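The compounds below may be only part of what the source reports. "The series", "measured", "known", "first", "only" and "open" are said of these compounds alone.

Compound 1 `Cc1c(C(=O)N[C@@H](C)c2ccc(C(=O)O)cc2)nnn1Cc1ccc(C(F)(F)F)cc1` in a functional assay on CHO cells for antagonist activity at prostaglandin E2 receptor EP4 subtype (Homo sapiens), read by calcium flux, with a stated time of 15 min (a higher number here means a weaker inhibitor, a lower number a stronger inhibitor), gives a value that is a limit of the assay, > 10000 nM. Compound 2 `CCc1c(C(=O)N[C@@H](C)c2ccc(C(=O)O)cc2)nnn1Cc1ccc(C(F)(F)F)cc1` in this assay also gives a limit, > 10000 nM. Compound 3 `CCc1nnn(Cc2ccc(C(F)(F)F)cc2)c1C(=O)N[C@@H](C)c1ccc(C(=O)O)cc1` in this assay likewise gives a limit, > 10000 nM.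

From compound 1 to compound 2 the change is methyl in place of hydrogen on a saturated chain carbon bound to an aromatic carbon, and the step it made is a step that the two limits leave unreadable from compound 1 to compound 2. The difference between the cores of compound 1 and compound 3 is not broken down here. Compound 4 `CCCc1nnn(Cc2ccc(C(F)(F)F)cc2)c1C(=O)N[C@@H](C)c1ccc(C(=O)O)cc1` has not yet been measured; it differs from compound 3 by methyl in place of hydrogen on a saturated chain carbon, two bonds along the chain from an aromatic carbon, the same kind of change as from compound 1 to compound 2, though here on a saturated chain carbon two bonds along the chain from an aromatic carbon rather than on one bound to an aromatic carbon. Because (the limit of > 10000 nM in this assay, at which 3 of the 3 values shown sit), there is no readable step to build on. The step from compound 3 to compound 4 is expected to be a step that the limit leaves unreadable from compound 3 to compound 4. Compound 4 is therefore estimated at 15000 nM in this assay, most likely again reported only as a limit.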

Compound 4, half-maximal inhibitory concentration: 68.8 nM
Compound 4: the middle estimate sits 220-fold (2.34 log units) above what was measured; the measured number lies below the stated range.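

Going from ethyl to propyl gave an at least 140-fold lower number from compound 3 to compound 4 (2.16 log units; beyond the scatter) in this assay, so on this core one added methyl, on a saturated chain carbon two bonds along the chain from an aromatic carbon, turned a limit into a measured value. This does not show that the gain carries over to the core of compound 1, where the step from methyl to ethyl sits on a saturated chain carbon bound to an aromatic carbon, a different place. That step cannot be read, since both of its ends are limits: the limit of > 10000 nM in this assay, at which 3 of the 4 values shown sit.

The compounds shown leave open what a propyl chain would do on the core of compound 1. They also leave open whether a butyl chain on the core of compound 4 would give a still lower number.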